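The source may hold more compounds than are shown below. What is called first, only, known or untested is meant among the compounds shown, and "the series" means these compounds.

Compound 1 `Cn1c(=O)c(C(=O)NCCCCCCN)c(O)c2ccccc21` gives 8.3% in a functional assay, with a stated time of 60 min, tested at 0.1 mM; on this read-out higher numbers stand for a stronger effect at the one concentration tested and lower numbers for a weaker effect.
Compound 2 `Cn1c(=O)c(C(=O)Nc2ccc(N)cc2)c(O)c2ccccc21` gives 88.1% in this assay.

Compound 1 stands lowest of these two numbers; its nearest neighbour is compound 2, reached by the step of a number 79.8 percentage points higher from compound 1 to compound 2 (beyond the scatter), which exchanges the whole group on the amide-type nitrogen. Compound 3 `Cn1c(=O)c(C(=O)NCCCCCCNC(=O)CCCCC2CCSS2)c(O)c2ccccc21` has not been measured. It differs from compound 1 by a group of 11 heavy atoms (8 carbon, 1 oxygen, 2 sulfur; one five-membered non-aromatic ring with 2 hetero atoms) in place of a hydrogen atom, on an amine nitrogen. Among the compounds with values here, no measured step touches this amine nitrogen, so the single known step, from compound 1 to compound 2, bears on it only indirectly: it shows that the part of the molecule beyond the amide-type nitrogen can move the number a great deal, but it tells nothing about what happens when the hydrogen on the terminal amine is replaced. From a starting point this low, a large downward step is hardly possible, while an upward one cannot be ruled out. Compound 3 is therefore expected to stay near its parent, a number 6.7 percentage points higher from compound 1 to compound 3 (within the scatter), with an estimate of 15% and a range from 0% to 50%.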

Compound 3, a percentage reported as activity, at one concentration (the size of the read-out at that concentration, not a potency): 13%
Estimate against measurement, compound 3: 2 percentage points above; the range from low to high includes it.
By their numbers in this assay, from the lowest: compounds 1 and 3 (each within the scatter of the next); then compound 2.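

In this assay, a group of 11 heavy atoms, including one five-membered non-aromatic ring with 2 hetero atoms, in place of a hydrogen atom on the amine nitrogen gives a number 4.7 percentage points higher from compound 1 to compound 3 (within the scatter). At this nitrogen, then, the read-out does not separate the hydrogen atom from this large group, unlike the swing at the amide-type nitrogen, a number 79.8 percentage points higher from compound 1 to compound 2 (beyond the scatter). Nothing measured here offers an explanation for this result.

This single group leaves open whether a different one on the same nitrogen, such as an acetyl group or a chain ending in a carboxylic acid, would behave alike. It also leaves open what the same group would do on the amine of the 4-aminophenyl ring in compound 2, which starts much higher at 88.1%.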